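A few compounds are considered here, and "the series" means these few. Any claim that something is new, unique, unknown or untested is made for them only; others in the source may bear on it.

Measured in a functional assay on A549 cells (Homo sapiens) for inhibition, read by MTT assay, with a stated time of 48 h; a higher number here means a weaker inhibitor, a lower number a stronger inhibitor:

- Compound 1 `Brc1ccc2[nH]cc(C(c3ccc4ccccc4c3)c3c[nH]c4ccc(Br)cc34)c2c1`: 8500 nM
- Compound 2 `N#Cc1ccc2[nH]cc(C(c3ccc([N+](=O)[O-])cc3)c3c[nH]c4ccc(C#N)cc34)c2c1`: > 100000 nM (a limit of the assay, not a number)
- Compound 3 `OC[C@H]1O[C@@H](n2cc(C(c3ccc(Cl)cc3)c3cn([C@@H]4O[C@H](CO)[C@@H](O)[C@H](O)[C@H]4O)c4ccc(Br)cc34)c3cc(Br)ccc32)[C@H](O)[C@@H](O)[C@@H]1O`: 2700 nM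

Only two of these results are true numbers. Compound 3 has the lower one, and compound 1 sits higher by a gap beyond the usual scatter, so compound 3 is the stronger inhibitor of the pair.

The next compound, compound 4 `O=[N+]([O-])c1ccc(C(c2cn([C@@H]3O[C@H](CO)[C@@H](O)[C@H](O)[C@H]3O)c3ccc(Br)cc23)c2cn([C@@H]3O[C@H](CO)[C@@H](O)[C@H](O)[C@H]3O)c3ccc(Br)cc23)cc1`, has nitro in place of chloro on an aromatic carbon, para to a large group, turning 4-chlorophenyl into 4-nitrophenyl: nitro in place of chloro on an aromatic carbon. Among the measured compounds shown here, no measured pair here shows this change alone. For the measured compounds named here, the only other compound with 4-nitrophenyl is compound 2, at > 100000 nM, which is a limit, and it differs from compound 4 in other ways too, so it is only a weak hint towards a weaker inhibitor.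

The expected change, a 2.2-fold higher number from compound 3 to compound 4 (0.35 log units; beyond the scatter), is therefore a modest rise, around the edge of the scatter. For compound 4 the estimated value is 6000 nM, with an expected range of 1500 nM to 40000 nM.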

Compound 4, half-maximal inhibitory concentration: 2400 nM
Compound 4: middle estimate off by 2.5-fold (0.40 log units), on the high side; low and high end bracket the measured number.
By their numbers in this assay, from the lowest: compounds 4 and 3 (each within the scatter of the next); then compound 1. At a limit, above all of these: compound 2.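

In this assay, putting nitro in place of chloro on this aromatic carbon gives a 1.1-fold lower number from compound 3 to compound 4 (0.05 log units; within the scatter). Among the compounds shown here, this is the first pair here that differs in one place only, and with the rest of the structure held fixed, 4-chlorophenyl and 4-nitrophenyl cannot be told apart in this assay. Compound 2 also carries 4-nitrophenyl, and its result is a limit of the assay, not a number: the limit of > 100000 nM in this assay, at which 1 of the 4 values shown sits.

For the compounds shown here, whether the swap would read the same on a different background stays open, since this is the only pair that shows it. Going by these compounds alone, also open is how an amine or a carboxylic acid would behave at this position, as chloro and nitro are the only two groups compared here.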